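A Methyl Added to the Isopropyl Group of Compound 3

The compounds below may be only part of what the source reports. "The series", "measured", "known", "first", "only" and "open" are said of these compounds alone.

Three compounds sharing one core differ only in the group on the amide-type nitrogen. Compound 1 `Cc1ccc(OCC(=O)N(Cc2cccs2)c2cnn(C)c2)cc1` carries a 1-methyl-1H-pyrazol-4-yl there, and in an assay on HEK293 cells for agonist activity at transient receptor potential cation channel subfamily M member 8 (Homo sapiens), read by fluorescence and calcium flux, with a stated time of 15 min (a lower number here means that less compound is needed, a higher number that more compound is needed for the effect), compound 1 gives 63000 nM. Compound 2 `Cc1ccc(OCC(=O)N(Cc2cccs2)C2COC2)cc1` carries an oxetan-3-yl and gives 23000 nM; the step between them is a 2.7-fold lower number from compound 1 to compound 2 (0.44 log units; beyond the scatter). Compound 3 `Cc1ccc(OCC(=O)N(Cc2cccs2)C(C)C)cc1` carries an isopropyl and gives 70 nM, the lowest of the three numbers; the steps leading to it are a 900-fold lower number from compound 1 to compound 3 (2.95 log units; beyond the scatter) and a 330-fold lower number from compound 2 to compound 3 (2.52 log units; beyond the scatter). Compound 4 `CCC(C)N(Cc1cccs1)C(=O)COc1ccc(C)cc1` extends this group: methyl in place of hydrogen on a saturated chain carbon, two bonds along the chain from an amide-type nitrogen. Among the measured compounds shown here, no measured step alters the group in so small a way; the two steps into compound 3 show that this nitrogen substituent matters greatly, but both replace a ring with isopropyl rather than lengthening a chain. A step of a 1.3-fold lower number from compound 3 to compound 4 (0.10 log units; within the scatter) is therefore expected, that is, little change beyond the scatter in either direction. Compound 4 is expected to give 55 nM, between 20 nM and 200 nM.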

Compound 4, half-maximal effective concentration: 2000 nM
Compound 4: the middle estimate sits 36-fold (1.56 log units) below what was measured; measured number outside the range, above it.
By their numbers in this assay, from the lowest: compound 3; then compound 4; then compound 2; then compound 1.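

In this assay this nitrogen substituent proves sensitive even to a very small addition: methyl in place of hydrogen on a saturated chain carbon, two bonds along the chain from an amide-type nitrogen, gives a 29-fold higher number from compound 3 to compound 4 (1.46 log units; beyond the scatter) and so turns isopropyl into a clearly different sec-butyl. Sec-butyl nonetheless stays well ahead of both ring groups, with a 12-fold lower number from compound 2 to compound 4 (1.06 log units; beyond the scatter) and a 32-fold lower number from compound 1 to compound 4 (1.50 log units; beyond the scatter) showing that the ring replacements cost more than the added methyl does. The data offer no evidence on what lies behind the size of the methyl step.

As far as these compounds go, whether a cyclopropyl or tert-butyl group would stay close to compound 3 remains open. So does whether an n-propyl or a longer chain on this nitrogen would follow compound 4.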